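The source may report more compounds than this note shows. Statements on the series, on what has been measured and on what is new or still open speak of the compounds shown alone.

Of the compounds shown here, three have numbers so far in a functional assay on SW 1116 cells (Homo sapiens) for antiproliferative activity, read by MTT assay, with a stated time of 48 h; a lower number here means a stronger inhibitor, a higher number a weaker inhibitor. Compound 1 (`Clc1ccccc1CSc1nnc(-c2cnccn2)s1`) gives 7530 nM and compound 2 (`Clc1ccc(CSc2nnc(-c3cnccn3)s2)cc1`) gives 4770 nM, two values within the scatter of each other. Compound 3 (`Clc1ccccc1CSc1nnc(-c2cnccn2)n1-c1ccccc1`) gives 18100 nM, the highest of the three numbers, which makes it the weakest inhibitor of the set, and its gaps to both others lie beyond the scatter.

Compound 4 (`Fc1cccc(F)c1CSc1nnc(-c2cnccn2)n1-c1ccccc1`) has not been measured yet. It keeps the rest of compound 3 but carries 2,6-difluorophenyl in place of 2-chlorophenyl on a saturated chain carbon bound to a sulfur. Among the compounds with values here, no measured pair shows this swap on its own, so the data offer no direct guide and the expectation is a cautious one. The estimated step in this assay, a 1.2-fold lower number from compound 3 to compound 4 (0.08 log units; within the scatter), is small and stays within the scatter, with only a slight lean towards a lower number. For compound 4 the expected value is 15000 nM, with an estimated range from 6000 nM to 38000 nM.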

Compound 4, half-maximal inhibitory concentration: 24100 nM
Estimate against measurement, compound 4: 1.6-fold (0.21 log units) below; low and high end bracket the measured number.
By their numbers in this assay, from the lowest: compounds 2 and 1 (each within the scatter of the next); then compounds 3 and 4 (each within the scatter of the next).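

In this assay the change to 2,6-difluorophenyl in place of 2-chlorophenyl on a saturated chain carbon bound to a sulfur gives a 1.3-fold higher number from compound 3 to compound 4 (0.12 log units; within the scatter) and stays within the scatter. Within the data shown here, this is the first single-place comparison, and it shows that replacing the lone chlorine with two fluorine atoms on this ring leaves the number indistinguishable from that of compound 3. Nothing measured here offers an explanation for this result.

Going by these compounds, both groups compared at this place are halogen-bearing phenyl rings, so it remains open whether an unsubstituted phenyl, a methoxy-bearing phenyl or a ring carrying a carboxylic acid would shift the number beyond the scatter. On these data alone, it also remains open whether the same swap would give a similar result on the core of compound 1.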